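This account rests on a few compounds, and the source may have more. Where it says the series, first, only, none or still open, it means among the compounds named here.

Compounds 1, 2 and 3 share one core and differ only on the saturated ring attached to the carbonyl. Compound 1 `CO[C@]1(C(=O)N2CC[C@](c3ccc(C(F)(C(F)(F)F)C(F)(F)F)cc3)(S(=O)(=O)c3ccc(F)cc3)C2)CC[C@H](C(=O)O)CC1` carries a methoxy on a saturated ring carbon; in an ADME assay on microsomes from liver (Mus musculus) for metabolic stability, with a stated time of 10 min (on this read-out lower numbers stand for a less stable compound and higher numbers for a more stable compound), compound 1 gives 95%. Compound 2 `COC[C@]1(C(=O)N2CC[C@](c3ccc(C(F)(C(F)(F)F)C(F)(F)F)cc3)(S(=O)(=O)c3ccc(F)cc3)C2)CC[C@H](C(=O)O)CC1` gives 88%, the lower of the two single numbers, and the step of a number 7 percentage points lower from compound 1 to compound 2 (within the scatter). Compound 3 `O=C(O)C1CCC(O)(C(=O)N2CC[C@](c3ccc(C(F)(C(F)(F)F)C(F)(F)F)cc3)(S(=O)(=O)c3ccc(F)cc3)C2)CC1` gives 99%; 98% (2 entries), and its repeated entries the several entries of compound 3 in this assay, 99%; 98% (2 entries) agree closely. Compound 4 `O=C([C@H]1CC[C@H](c2nnn[nH]2)CC1)N1CC[C@](c2ccc(C(F)(C(F)(F)F)C(F)(F)F)cc2)(S(=O)(=O)c2ccc(F)cc2)C1` differs from compound 2 in one place: 4-(1H-tetrazol-5-yl)cyclohexyl in place of 4-carboxy-1-(methoxymethyl)cyclohexyl on a carbonyl carbon. For the measured compounds named here, the only measured step, from compound 1 to compound 2, is small and touches another part of the ring, so it says little about this exchange. All measured numbers sit high; compound 4 is estimated at 85% (from 65% to 97%), a step of a number 3 percentage points lower from compound 2 to compound 4 (within the scatter) expected to stay modest.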

Compound 4, percent of the compound remaining: 73%
The estimate for compound 4 lay 12 percentage points above the measured number; the measured number falls inside the stated range.
By their numbers in this assay, from the lowest: compound 4; then compounds 2 and 1 (each within the scatter of the next).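

In this assay, for the compounds shown here, this is the first exchange on the carbonyl carbon that clears the scatter, with a number 15 percentage points lower from compound 2 to compound 4 (beyond the scatter) and with a number 22 percentage points lower from compound 1 to compound 4 (beyond the scatter) as well. The exchange brings in the 1H-tetrazol-5-yl ring and also removes the carboxy group together with the methoxymethyl or methoxy group, so the ring attached to the carbonyl does respond to change. Nothing shown here explains the drop. Which part of the exchange drives the step stays open, since these parts changed together. A tetrazole kept alongside a methoxy group, or a primary amide in its place, could still read differently.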